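The source may hold more compounds than are shown below. What is called first, only, known or untested is meant among the compounds shown, and "the series" means these compounds.

Compound 1 `CCCOc1ccc2[nH]c(-c3ccc(OC)cc3)c(C3=C(Br)C(=O)NC3=O)c2c1` and compound 2 `CCCCOc1ccc2[nH]c(-c3ccc(OC)cc3)c(C3=C(Br)C(=O)NC3=O)c2c1` share one core. In a physicochemical assay for lipophilicity (on this read-out lower numbers stand for lower lipophilicity and higher numbers for higher lipophilicity), compound 1 gives 3.12, and compound 2 gives 3.43. The change methyl in place of hydrogen on a saturated chain carbon, three bonds along the chain from an oxygen on an aromatic ring made a step of a number 0.31 log units higher from compound 1 to compound 2 (beyond the scatter). Compound 3 `CCc1cccc2c(C3=C(Br)C(=O)NC3=O)c(-c3ccc(OC)cc3)[nH]c12` rests on another core; the difference between the two cores is not broken down here. In this assay compound 3 gives 3.35, which lies within the scatter of compound 2 and of compound 1. Compound 4 `CCCc1cccc2c(C3=C(Br)C(=O)NC3=O)c(-c3ccc(OC)cc3)[nH]c12` has not been measured. It arises from compound 3 by the change (methyl in place of hydrogen on a saturated chain carbon, two bonds along the chain from an aromatic carbon), the same kind of change as that from compound 1 to compound 2, though here the place is a saturated chain carbon two bonds along the chain from an aromatic carbon rather than three bonds along the chain from an oxygen on an aromatic ring. Among the compounds with values here, the expectation for compound 4 rests on the earlier step of a number 0.31 log units higher from compound 1 to compound 2 (beyond the scatter), the only measured step of this kind. Compound 4 is expected to show a step of a number 0.35 log units higher from compound 3 to compound 4 (beyond the scatter) in this assay. Compound 4 is therefore estimated at 3.7, between 3.4 and 4.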

Compound 4, partition coefficient: 3.58
Compound 4: middle estimate off by 0.12 log units, on the high side; measured number inside the range.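

In this assay, the change carried over to the core of compound 3 gives a number 0.23 log units higher from compound 3 to compound 4 (within the scatter), whereas on the core of compound 1 it gave a number 0.31 log units higher from compound 1 to compound 2 (beyond the scatter), so one step lies within the scatter and the other beyond it. This shows that a step beyond the scatter on one core did not carry over as such to the other, but with a single pair on each core, and with the change at a different place on the chain, it does not show that the two cores truly respond differently to the added methyl. Nothing available here explains the two readings.

The compounds shown leave open whether a longer chain, such as butyl in place of the propyl of compound 4, would give a step beyond the scatter on this core. They also leave open how a chain carrying an amine or a carboxylic acid would read on either core.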